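Methylsulfonyl in place of methylsulfanyl: the outlook for compound 4

The source may report more compounds than this note shows. Statements on the series, on what has been measured and on what is new or still open speak of the compounds shown alone.

Compound 1 `CSc1c(F)cccc1NCC1=NCCN1` and compound 3 `CSc1ccc(C(F)(F)F)cc1NCC1=NCCN1` share a core; how the two cores differ is not broken down here. In a functional assay for agonist activity at Alpha-1D adrenergic receptor (Homo sapiens) (on this read-out higher numbers stand for an effect only at larger amounts of compound and lower numbers for an effect already at smaller amounts), compound 1 gives 33.9 nM, and compound 3 gives 43.7 nM, and these two values lie within the usual scatter of each other. Compound 2 `CS(=O)(=O)c1c(F)cccc1NCC1=NCCN1` differs from compound 1 by methylsulfonyl in place of methylsulfanyl on an aromatic carbon. For compound 2 the value in this assay is a limit, < 100000 nM, not a number. The step that the limit leaves unreadable from compound 1 to compound 2 therefore cannot be sized, as the limit of < 100000 nM in this assay, at which 1 of the 3 values shown sits, shows. Compound 4 `CS(=O)(=O)c1ccc(C(F)(F)F)cc1NCC1=NCCN1` differs from compound 3 by methylsulfonyl in place of methylsulfanyl on an aromatic carbon, the same kind of change, though here the place is para to a trifluoromethyl group rather than ortho to a fluoro group. Because compound 1 moved to a limit in a step that the limit leaves unreadable from compound 1 to compound 2, compound 4 is expected to weaken by a 690-fold higher number from compound 3 to compound 4 (2.84 log units; beyond the scatter) in this assay, with a real chance that only a limit is reported again. The estimate for compound 4 is 30000 nM, expected to lie between 2000 nM and 100000 nM.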

Compound 4, half-maximal effective concentration: < 100000 nM
Compound 4: only a limit was reported (the forecaster's own chance of this, stated with the estimate: 60%); the middle value lies beyond the limit too.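

In this assay compound 4 gives < 100000 nM, which is a limit and not a number, so the change from compound 3 to compound 4 cannot be read as a step. The compounds shown leave open how large the effect of methylsulfonyl in place of methylsulfanyl on an aromatic carbon is, from compound 1 to compound 2 or from compound 3 to compound 4: the limit of < 100000 nM in this assay, at which 2 of the 4 values shown sit.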